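The source may report more compounds than this note shows. Statements on the series, on what has been measured and on what is new or still open speak of the compounds shown alone.

Working notes on a small series tested in a functional assay on SK-OV-3 cells (Homo sapiens) for inhibition, read by sulforhodamine B assay, with a stated time of 48 h; a lower number here means a stronger inhibitor of growth, a higher number a weaker inhibitor of growth. Compound 1 `COc1cc(OC)cc(-c2ccc(-c3ccc(C(=N)N)c(F)c3)s2)c1` gives 1640 nM. Compound 2 `N=C(N)c1ccc(-c2ccc(-c3ccc(Cl)cc3)s2)cc1F` gives 1140 nM; the two numbers lie within the usual scatter of each other, so no order is drawn between them. The difference between the core of compound 1 and the core of compound 2 is not broken down here. Compound 3 `N=C(N)c1ccc(-c2ccc(-c3ccc(Cl)cc3)s2)cc1` gives 246 nM. Compound 3 arises from compound 2 by hydrogen in place of fluoro on an aromatic carbon and this change gave a 4.6-fold lower number from compound 2 to compound 3 (0.67 log units; beyond the scatter).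

Compound 4 `COc1cc(OC)cc(-c2ccc(-c3ccc(C(=N)N)cc3)s2)c1` is not yet measured in this assay. It arises from compound 1 by hydrogen in place of fluoro on an aromatic carbon, which is the same change, at the same place, as that leading from compound 2 to compound 3; among the compounds shown this change occurs twice in all. Among the compounds with values here, the only measured instance of it is a modest step beyond the scatter, and nothing in the data suggests the change should behave differently on the core of compound 1, though a single precedent carries uncertainty. Within the data shown here, a step of comparable size is therefore expected, estimated as a 4.6-fold lower number from compound 1 to compound 4 (0.66 log units; beyond the scatter), resting on the one measured step of a 4.6-fold lower number from compound 2 to compound 3 (0.67 log units; beyond the scatter). For compound 4 the expected value in this assay is 360 nM, with a likely range from 130 nM to 1000 nM.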

Compound 4, concentration for 50% growth inhibition: 2080 nM
Estimate against measurement, compound 4: 5.8-fold (0.76 log units) below; measured number outside the range, above it.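

On the core of compound 1, hydrogen in place of fluoro gives a 1.3-fold higher number from compound 1 to compound 4 (0.10 log units; within the scatter), so compound 1 and compound 4 cannot be told apart in this assay, whereas the same change on the other core gives a 4.6-fold lower number from compound 2 to compound 3 (0.67 log units; beyond the scatter). In this series the step measured on one core therefore does not carry over in size to the other, as the two steps set side by side show: the same change on two cores in this assay, a 4.6-fold lower number (0.67 log units; beyond the scatter) from compound 2 to compound 3 and a 1.3-fold higher number (0.10 log units; within the scatter) from compound 1 to compound 4, 5.9-fold (0.77 log units) apart, beyond the scatter of two such steps

This shows that the outcome of this change depends on the core in these two pairs, but two cores are too few for a rule, and the data do not show which feature of the cores accounts for the gap or which of the two steps a further core would resemble.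

The cores shown differ by a chloro group in one and two methoxy groups in the other, so it remains open how the same change behaves with a single methoxy group, or with a methyl or a nitrile in that part of the molecule. The amidine is also common to all four compounds, which leaves open whether the step would hold with an amine or a carboxylic acid in its place.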